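The source may hold more compounds than are shown below. What is called first, only, known or untested is meant among the compounds shown, and "the series" means these compounds.

Measured compounds:
- compound 1: `COc1cc(-c2cc(/C=C/C(=O)c3ccc(Cl)c(Cl)c3)[nH]n2)cc(OC)c1OC`, 10800 nM
- compound 2: `COc1ccc(C(=O)/C=C/c2cc(-c3cc(OC)c(OC)c(OC)c3)n[nH]2)cc1OC`, 2690 nM

In a functional assay on OVCAR-4 cells (Homo sapiens) for inhibition, read by sulforhodamine B assay, with a stated time of 48 h (on this read-out higher numbers stand for weaker inhibition of growth and lower numbers for stronger inhibition of growth), compound 2 gives the lower of the two numbers, with compound 1 giving a higher number in this assay. Among the measured compounds shown here, the one change recorded so far, a 4.0-fold lower number from compound 1 to compound 2 (0.60 log units; beyond the scatter), came from putting 3,4-dimethoxyphenyl in place of 3,4-dichlorophenyl on a carbonyl carbon.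

Compound 3, `COc1cc(-c2cc(/C=C/C(=O)c3ccc(F)c(F)c3)[nH]n2)cc(OC)c1OC`, has not yet been measured. It differs from compound 2 in one place: 3,4-difluorophenyl in place of 3,4-dimethoxyphenyl on a carbonyl carbon. For the measured compounds named here, this step runs in the reverse sense of the only measured step, returning a halogen pair to the same ring on the carbonyl carbon, so the expected direction is toward a higher number. Because the measured step of a 4.0-fold lower number from compound 1 to compound 2 (0.60 log units; beyond the scatter) was modest but beyond the scatter, the expected step for compound 3 is a 2.6-fold higher number from compound 2 to compound 3 (0.42 log units; beyond the scatter). The estimate for compound 3 in this assay is 7000 nM, with a range from 2500 nM to 20000 nM.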

Compound 3, concentration for 50% growth inhibition: 2200 nM
Compound 3: the middle estimate sits 3.2-fold (0.50 log units) above what was measured; measured number outside the range, below it.
By their numbers in this assay, from the lowest: compounds 3 and 2 (each within the scatter of the next); then compound 1.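

Within this assay the swap of 3,4-dimethoxyphenyl for 3,4-difluorophenyl on the carbonyl carbon gives a 1.2-fold lower number from compound 2 to compound 3 (0.09 log units; within the scatter) so these two groups cannot be told apart here. Replacing 3,4-dichlorophenyl with 3,4-difluorophenyl at the same place gives a 4.9-fold lower number from compound 1 to compound 3 (0.69 log units; beyond the scatter) so a halogen pair on this ring does not in itself go with the weaker growth inhibition, and among these three compounds only the 3,4-dichlorophenyl group of compound 1 stands apart. Nothing measured here explains why the chlorine pair and the fluorine pair differ.

On these data alone, it remains open whether a plain phenyl ring, a 3,4-dimethylphenyl group or a ring carrying an amine or a carboxylic acid would fall with compound 1 or with compounds 2 and 3. As far as these compounds go, whether a single fluorine would match the fluorine pair is also open.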